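Methoxy placement on the aryl arm of the acrylic acid series

This account rests on a few compounds, and the source may have more. Where it says the series, first, only, none or still open, it means among the compounds named here.

In a functional assay on LNCaP cells (Homo sapiens) for cytotoxicity, read by MTT assay, with a stated time of 72 h (a higher number here means a weaker inhibitor, a lower number a stronger inhibitor), compound 3 `COc1ccc(/C(=C\c2cn(C(C)=O)c3ccc(OCc4ccccc4)cc23)C(=O)O)cc1` gives 85000 nM. Compound 2 `COc1cc(/C(=C\c2cn(C(C)=O)c3ccc(OCc4ccccc4)cc23)C(=O)O)cc(OC)c1OC` gives 59600 nM in this assay, and the gap a 1.4-fold higher number from compound 2 to compound 3 (0.15 log units; within the scatter) is within the scatter, so the two cannot be ordered. Compound 1 `COc1cc(OC)cc(/C(=C\c2cn(C(C)=O)c3ccc(OCc4ccccc4)cc23)C(=O)O)c1` gives 26100 nM in this assay, and the step of a 3.3-fold higher number from compound 1 to compound 3 (0.51 log units; beyond the scatter) is beyond the scatter, so compound 3 stands at the high end of the three numbers, clearly apart only from compound 1.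

Compound 4 `COc1cccc(/C(=C\c2cn(C(C)=O)c3ccc(OCc4ccccc4)cc23)C(=O)O)c1` differs from compound 3 by 3-methoxyphenyl in place of 4-methoxyphenyl on a double-bonded chain carbon bound to a carbonyl carbon and a double-bonded chain carbon. The measured steps that touch this position are a 2.3-fold higher number from compound 1 to compound 2 (0.36 log units; beyond the scatter), where adding a methoxy group on an aromatic carbon raised the number, and a 3.3-fold higher number from compound 1 to compound 3 (0.51 log units; beyond the scatter), where the 3,5-dimethoxyphenyl gave the lower number. The 3-methoxyphenyl of compound 4 keeps one of the two methoxy groups of compound 1 and drops the methoxy that in compound 3 carries the highest number, so a number between those of compound 1 and compound 3 is expected. The step of a 1.9-fold lower number from compound 3 to compound 4 (0.28 log units; within the scatter) is expected to be modest and downward. Compound 4 is estimated at 45000 nM in this assay, with a range from 20000 nM to 100000 nM.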

Compound 4, half-maximal inhibitory concentration: 65100 nM
Compound 4: middle estimate off by 1.4-fold (0.16 log units), on the low side, and the stated range covers the measured number.
By their numbers in this assay, from the lowest: compound 1; then compounds 2, 4 and 3 (each within the scatter of the next).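

Moving the single methoxy from the 4-methoxyphenyl to the 3-methoxyphenyl on this double-bonded chain carbon does not register in this assay: the step of a 1.3-fold lower number from compound 3 to compound 4 (0.12 log units; within the scatter) cannot order the two placements. Swapping the 3,4,5-trimethoxyphenyl for the 3-methoxyphenyl likewise gives no readable change, at a 1.1-fold higher number from compound 2 to compound 4 (0.04 log units; within the scatter), while removing one methoxy from the 3,5-dimethoxyphenyl does give a readable one, at a 2.5-fold higher number from compound 1 to compound 4 (0.40 log units; beyond the scatter), so the number at this position does not follow the methoxy count, and only compound 1 stands clearly apart from the other three, with the lowest number. No measurement on hand accounts for this pattern.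

Still open, from the compounds shown here alone, is whether the lower number of compound 1 depends on the 3,5-dimethoxyphenyl itself or on any two methoxy groups on this ring, which a 3,4-dimethoxyphenyl would test. Also open, going by these compounds, is whether a group other than methoxy on this aryl arm, such as a hydroxyl, a fluorine or an amine, would shift the number beyond the scatter.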